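Series notes: from compound 3 to compound 4

The source may report more compounds than this note shows. Statements on the series, on what has been measured and on what is new or still open speak of the compounds shown alone.

Compound 1 `CC(=O)N1CCc2nc(C)c(C(OC(C)(C)C)C(=O)O)c(-c3ccc(C)cc3)c2C1` gives only a limit in an ADME assay on MT2 cells (Homo sapiens) for cytotoxicity, read by XTT assay, with a stated time of 4 days (on this read-out higher numbers stand for lower toxicity in this test and lower numbers for higher toxicity in this test), namely > 40000 nM. Compound 2 `Cc1ccc(-c2c3c(nc(C)c2[C@H](OC(C)(C)C)C(=O)O)CCN(CCCc2ccccc2)C3)cc1` likewise gives a limit in this assay, > 40000 nM. Compound 3 `Cc1nc2c(c(-c3cc(F)c4c(c3C)CCCO4)c1[C@H](OC(C)(C)C)C(=O)O)CN(CCCc1ccc(F)cc1)CC2` also stands at a limit in this assay, > 40000 nM, so no number sets it apart from the others; every value shown sits at the same limit (the limit of > 40000 nM in this assay, at which 3 of the 3 values shown sit). Compound 4 `Cc1nc2c(c(-c3cc(F)c4c(c3C)CCCO4)c1[C@H](OC(C)(C)C)C(=O)O)CN(CC1CC1c1ccccc1)CC2` is not yet measured. It differs from compound 3 by 2-phenylcyclopropyl in place of 2-(4-fluorophenyl)ethyl on a saturated chain carbon bound to an amine nitrogen in a ring. Within the data shown here, no measured step exists between neighbouring compounds in this assay, so nothing beyond the scatter is expected from compound 3 to compound 4, the expected step being a number no higher from compound 3 to compound 4 (the limit leaves the size open). Compound 4 is estimated at 40000 nM, in the range 15000 nM to 40000 nM, and is expected to return only a limit again.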

Compound 4, half-maximal cytotoxic concentration: > 40000 nM
Compound 4 was reported as a limit; the forecaster's own chance of this, stated with the estimate: 80%; the middle value lies on the limit itself.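

Compound 3 and compound 4 both stand at a limit in this assay, so no step can be read between them: the limit of > 40000 nM in this assay, at which 4 of the 4 values shown sit.

The compounds shown leave open at what concentration any of them turns cytotoxic in this assay.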